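More Fluorines on the Phenoxy Group of Compound 3

The source may hold more compounds than are shown below. What is called first, only, known or untested is meant among the compounds shown, and "the series" means these compounds.

Three compounds sharing one core differ only in the aryl group on an oxygen on a saturated carbon. Compound 1 `CC(C)[C@H](NC(=O)COc1cccc2ccccc12)C(=O)N[C@@H](CC(=O)O)C(=O)COc1ccc([N+](=O)[O-])cc1` carries a 4-nitrophenyl there; in a functional assay on Jurkat cells (Homo sapiens) (on this read-out lower numbers stand for stronger inhibition and higher numbers for weaker inhibition), compound 1 reaches only the limit of the assay, > 100000 nM. Compound 2 `CC(C)[C@H](NC(=O)COc1cccc2ccccc12)C(=O)N[C@@H](CC(=O)O)C(=O)COc1ccc(F)cc1` carries a 4-fluorophenyl; in this assay compound 2 likewise stops at the limit, > 100000 nM. Compound 3 `CC(C)[C@H](NC(=O)COc1cccc2ccccc12)C(=O)N[C@@H](CC(=O)O)C(=O)COc1ccc(F)cc1F` carries a 2,4-difluorophenyl, and in this assay compound 3 gives 33200 nM, the only true number among the three shown. The steps leading to it are an at least 3.0-fold lower number from compound 1 to compound 3 (0.47 log units; beyond the scatter) and an at least 3.0-fold lower number from compound 2 to compound 3 (0.47 log units; beyond the scatter), while the step that the two limits leave unreadable from compound 1 to compound 2 cannot be sized because of the limit of > 100000 nM in this assay, at which 2 of the 3 values shown sit.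

Compound 4 `CC(C)[C@H](NC(=O)COc1cccc2ccccc12)C(=O)N[C@@H](CC(=O)O)C(=O)COc1c(F)c(F)c(F)c(F)c1F` is not yet measured. It differs from compound 3 by 2,3,4,5,6-pentafluorophenyl in place of 2,4-difluorophenyl on an oxygen on a saturated carbon. Within the data shown here, the one readable step, an at least 3.0-fold lower number from compound 2 to compound 3 (0.47 log units; beyond the scatter), came with a fluoro entering where hydrogen stood, and compound 4 carries further fluorines on the same ring. The account therefore expects a modest further fall for compound 4 in this assay, about a 2.2-fold lower number from compound 3 to compound 4 (0.35 log units; beyond the scatter). Compound 4 is estimated at 15000 nM, with a range from 4000 nM to 60000 nM.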

Compound 4, half-maximal inhibitory concentration: 3050 nM
The estimate for compound 4 lay 4.9-fold (0.69 log units) above the measured number, outside the stated range (below it).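

In this assay, among these compounds, the aryl group on this oxygen proves able to move the number far more than the earlier compounds could show: the 2,3,4,5,6-pentafluorophenyl gives an 11-fold lower number from compound 3 to compound 4 (1.04 log units; beyond the scatter). Among the fluorinated aryl groups shown, the number falls as fluorines are added, and this position now has two true numbers rather than one; the 4-nitrophenyl of compound 1 carries no fluorine and so does not test that trend. Against the two weakest compounds the change is also large, with an at least 32-fold lower number from compound 2 to compound 4 (1.51 log units; beyond the scatter) and an at least 32-fold lower number from compound 1 to compound 4 (1.51 log units; beyond the scatter), but both sizes are only lower bounds because they start from a limit: the limit of > 100000 nM in this assay, at which 2 of the 4 values shown sit.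

The compounds shown do not separate the number of fluorines from the places they occupy, since the ring gains fluorines at several places at once in the step to the 2,3,4,5,6-pentafluorophenyl. They also leave open whether fluorine itself matters here or whether another halogen would serve as well, as a chlorophenyl or a bromophenyl on the same oxygen would show.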